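The source may report more compounds than this note shows. Statements on the series, on what has been measured and on what is new or still open speak of the compounds shown alone.

In a functional assay on PANC-1 cells (Homo sapiens) for cytotoxicity, read by MTT assay, with a stated time of 24 h (a lower number here means a stronger inhibitor, a higher number a weaker inhibitor), compound 1 `CC(=O)N1C(=O)C=CCC1/C=C/c1ccccc1` gives 42300 nM, while compound 2 `C/C=C/C(=O)N1C(=O)C=CCC1/C=C/c1ccccc1` gives 4200 nM. Compound 2 therefore holds the lower of the two numbers, making it the stronger inhibitor of this pair. For the measured compounds named here, the one measured step, a 10-fold lower number from compound 1 to compound 2 (1.00 log units; beyond the scatter), came from placing prop-1-en-1-yl where methyl stood on a carbonyl carbon.

The next compound is compound 3 `O=C1C=CCC(/C=C/c2ccccc2)N1C(=O)/C=C/c1ccccc1`, which differs from compound 2 as follows: phenyl in place of methyl on a double-bonded chain carbon bound to a double-bonded chain carbon. Phenyl takes the place of methyl on a double-bonded chain carbon bound to a double-bonded chain carbon, so prop-1-en-1-yl becomes 2-phenylethenyl.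

Going by the values given here, only one measured step bears on this change, and a single step cannot establish a trend. Resting on a 10-fold lower number from compound 1 to compound 2 (1.00 log units; beyond the scatter), which altered the group on the same carbonyl carbon, a much smaller further fall is expected in this assay, possibly none beyond the scatter. The expected change is a 1.7-fold lower number from compound 2 to compound 3 (0.23 log units; within the scatter). For compound 3 the estimate is 2500 nM, with an expected range from 800 nM to 8000 nM.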

Compound 3, half-maximal inhibitory concentration: 16300 nM
Estimate against measurement, compound 3: 6.5-fold (0.81 log units) below; the whole stated range lies below it.
By their numbers in this assay, from the lowest: compound 2; then compound 3; then compound 1.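

In this assay, for the compounds shown here, the fall seen on the first change at this carbonyl carbon does not carry on: phenyl in place of methyl on a double-bonded chain carbon bound to a double-bonded chain carbon gives a 3.9-fold higher number from compound 2 to compound 3 (0.59 log units; beyond the scatter) and so reverses part of the earlier gain. The 2-phenylethenyl group still improves on the original methyl, with a 2.6-fold lower number from compound 1 to compound 3 (0.41 log units; beyond the scatter), so the number does not follow a steady line as the group on the carbonyl carbon grows: of these three compounds, the one carrying prop-1-en-1-yl has the lowest number, and the one carrying 2-phenylethenyl falls in the middle. Nothing in the information available explains why phenyl at the end of this chain raises the number relative to methyl.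

Still open, from the compounds shown here alone, is whether a longer plain chain, such as but-1-en-1-yl, would keep the low number of compound 2 or whether it would move the way phenyl does. Also open, going by these compounds, is whether adding a methoxy group or an amine to the phenyl of compound 3 would lower its number, raise it or leave it unchanged.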